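The source may hold more compounds than are shown below. What is called first, only, known or untested is meant among the compounds shown, and "the series" means these compounds.

Compound 3 `CC(C)=CCC/C(C)=C/CC/C(C)=C/CC[C@@H]1[C@@]2(C)C/C(=C\c3ccc(OCc4cn(-c5ccccc5C#N)nn4)cc3)C(=O)C(C)(C)[C@@H]2CC[C@@]1(C)O` is one of three analogues sharing a core that differ only in the aryl group on the aromatic nitrogen of the triazole. In a functional assay on MCF7 cells (Homo sapiens) for cytotoxicity, read by MTT assay, with a stated time of 48 h (on this read-out higher numbers stand for weaker inhibition and lower numbers for stronger inhibition), compound 3 gives 29900 nM. Compound 1 `CC(C)=CCC/C(C)=C/CC/C(C)=C/CC[C@@H]1[C@@]2(C)C/C(=C\c3ccc(OCc4cn(-c5ccc(F)cc5)nn4)cc3)C(=O)C(C)(C)[C@@H]2CC[C@@]1(C)O` gives 42000 nM in this assay, and compound 2 `CC(C)=CCC/C(C)=C/CC/C(C)=C/CC[C@@H]1[C@@]2(C)C/C(=C\c3ccc(OCc4cn(-c5ccc(Cl)cc5)nn4)cc3)C(=O)C(C)(C)[C@@H]2CC[C@@]1(C)O` gives 72400 nM. Among the measured compounds shown here, compound 3 thus gives the smallest of the three numbers, but the step of a 1.4-fold lower number from compound 1 to compound 3 (0.15 log units; within the scatter) is within the scatter; only the step of a 2.4-fold lower number from compound 2 to compound 3 (0.38 log units; beyond the scatter) is beyond it, and modestly so. Compound 4 `CC(C)=CCC/C(C)=C/CC/C(C)=C/CC[C@@H]1[C@@]2(C)C/C(=C\c3ccc(OCc4cn(-c5cccc([N+](=O)[O-])c5)nn4)cc3)C(=O)C(C)(C)[C@@H]2CC[C@@]1(C)O` carries the change (3-nitrophenyl in place of 2-cyanophenyl on an aromatic nitrogen). All three measured steps bear on this change, since each swaps the aryl group at the same position: a 1.7-fold higher number from compound 1 to compound 2 (0.24 log units; within the scatter), a 1.4-fold lower number from compound 1 to compound 3 (0.15 log units; within the scatter) and a 2.4-fold lower number from compound 2 to compound 3 (0.38 log units; beyond the scatter). None of them moved the number by much, so a further aryl swap is expected to give a step of the order of a 1.3-fold higher number from compound 3 to compound 4 (0.13 log units; within the scatter), that is, nothing clearly beyond the scatter. Compound 4 is therefore estimated at 40000 nM, with a range from 15000 nM to 110000 nM.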

Compound 4, half-maximal inhibitory concentration: 79400 nM
Compound 4: middle estimate off by 2.0-fold (0.30 log units), on the low side, within the range that was stated.
By their numbers in this assay, from the lowest: compounds 3, 1, 2 and 4 (each within the scatter of the next, the first and the last beyond it).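

In this assay the swap of 2-cyanophenyl for 3-nitrophenyl on the aromatic nitrogen gives a 2.7-fold higher number from compound 3 to compound 4 (0.42 log units; beyond the scatter) and is the second step at this position to pass the scatter, again modestly and again with compound 3 at the low end. The other new steps, a 1.1-fold higher number from compound 2 to compound 4 (0.04 log units; within the scatter) and a 1.9-fold higher number from compound 1 to compound 4 (0.28 log units; within the scatter), stay within the scatter, so a nitro group at this aryl ring cannot be told apart from the halogens of compound 1 and compound 2. Compound 3 now stands clear of both compound 2 and compound 4, though it remains within the scatter of compound 1, so the 2-cyanophenyl group has no clear lead over all the others.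

Every aryl group shown is a substituted phenyl, so an amine or a carboxylic acid on that ring, or a longer chain in its place, remains open. Nothing shown accounts for the differences among these aryl groups.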